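Replacing the 2-carboxypiperidin-1-yl group of compound 2

The source may hold more compounds than are shown below. What is called first, only, known or untested is meant among the compounds shown, and "the series" means these compounds.

Measured so far in an ADME assay on the whole organism (Rattus norvegicus) for metabolic stability, at a dose of 1 mg/kg by the intravenous route (on this read-out lower numbers stand for a shorter-lived compound and higher numbers for a longer-lived compound), as follows
- Compound 1 (`Cc1c(-c2ccc3c(c2)OCCO3)cccc1C(F)(F)Oc1cc(OCc2cncc(C#N)c2)c(CNC(CO)(CO)CO)cc1Cl`) with 1.32 h
- Compound 2 (`Cc1c(-c2ccc3c(c2)OCCO3)cccc1C(F)(F)Oc1cc(OCc2ccnc(C#N)c2)c(CN2CCCC[C@H]2C(=O)O)cc1Cl`) with 0.71 h

Compound 2, at 0.71 h on this read-out, lies within the usual scatter of compound 1, so the two values cannot be told apart. Compound 3 (`Cc1c(-c2ccc3c(c2)OCCO3)cccc1C(F)(F)Oc1cc(OCc2ccnc(C#N)c2)c(CN[C@@H]2C(O)O[C@H](CO)[C@@H](O)[C@@H]2O)cc1Cl`) changes one place of compound 2, a saturated chain carbon bound to an aromatic carbon, where the 2-carboxypiperidin-1-yl group goes: a group of 12 heavy atoms (6 carbon, 1 nitrogen, 5 oxygen; one six-membered non-aromatic ring with 1 hetero atom) in place of a group of 9 heavy atoms (6 carbon, 1 nitrogen, 2 oxygen; one six-membered non-aromatic ring with 1 hetero atom), on a saturated chain carbon bound to an aromatic carbon. Going by the values given here, no measured pair differs in one place only, so nothing yet shows directly what such a swap does. Compound 1, whose group in that place also bears hydroxyl groups, gives 1.32 h and suggests only a slight upward lean. The expected change is a 1.4-fold higher number from compound 2 to compound 3 (0.15 log units; within the scatter), which is estimated to stay within the scatter. Compound 3 is expected at 1 h, with an estimated range from 0.45 h to 2.2 h in this assay here.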

Compound 3, half-life: 4.84 h
Estimate against measurement, compound 3: 4.8-fold (0.68 log units) below; measured number above the stated range.
By their numbers in this assay, from the lowest: compounds 2 and 1 (each within the scatter of the next); then compound 3.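

In this assay, going by these compounds alone, this is the first comparison that changes only the group on the saturated chain carbon bound to an aromatic carbon. Exchanging the 2-carboxypiperidin-1-yl group for the larger ring bearing several hydroxyl groups gives a 6.8-fold higher number from compound 2 to compound 3 (0.83 log units; beyond the scatter), so the group at this position can shift half-life by more than the usual scatter. Nothing available explains why the number rises.

The swap changes several features at once, removing the carboxylic acid, adding hydroxyl groups and replacing the ring, so the compounds shown cannot assign the rise to any one of them. Also open, from the compounds shown here alone, is how a plain piperidine without the carboxylic acid, or a six-membered ring carrying a single hydroxyl group, would behave at this position.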